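A Chloroanilino Swap Tested on a Benzamide Core

The compounds below may be only part of what the source reports. "The series", "measured", "known", "first", "only" and "open" are said of these compounds alone.

Of the compounds shown here, three have been measured in a functional assay on HCT-116 cells (Homo sapiens) for antiproliferative activity, read by CCK-8 assay, with a stated time of 72 h, tested at 8 uM; a lower number here means a weaker effect, a higher number a stronger effect of the compound at the concentration tested. Compound 1 `CC1CCN(c2nc(Cl)nc3c2ncn3Cc2ccc(/C=C/C(=O)Nc3ccccc3N)cc2)CC1` gives 26.9%. Compound 2 `Nc1ccccc1NC(=O)/C=C/c1ccc(Cn2cnc3c(Nc4cccc(Cl)c4)nc(Cl)nc32)cc1` gives 15.8%. Compound 3 `CC1CCN(c2nc(Cl)nc3c2ncn3Cc2ccc(C(=O)Nc3ccccc3N)cc2)CC1` gives 78.6%, the highest of the three numbers; its nearest neighbour, compound 1, lies well outside the usual scatter, and compound 2 lies still further away.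

Compound 2 differs from compound 1 in one place: (3-chlorophenyl)amino in place of 4-methylpiperidin-1-yl on an aromatic carbon. That change made a step of a number 11.1 percentage points lower from compound 1 to compound 2 (beyond the scatter). Compound 3 differs from compound 1 by another single change, ((2-aminophenyl)carbamoyl in place of 2-((2-aminophenyl)carbamoyl)ethenyl on an aromatic carbon), which made a step of a number 51.7 percentage points higher from compound 1 to compound 3 (beyond the scatter).

Compound 4 `Nc1ccccc1NC(=O)c1ccc(Cn2cnc3c(Nc4cccc(Cl)c4)nc(Cl)nc32)cc1` has not yet been measured in this assay. It differs from compound 3 by (3-chlorophenyl)amino in place of 4-methylpiperidin-1-yl on an aromatic carbon. For the measured compounds named here, this is the same change as the one from compound 1 to compound 2, at a place described in the same words, but on the core of compound 3 rather than the core of compound 1; how the two cores differ is given by (2-aminophenyl)carbamoyl in place of 2-((2-aminophenyl)carbamoyl)ethenyl on an aromatic carbon. Going by the values given here, only one earlier example of this change exists here, so the expectation rests on it alone. A step of a number 12.6 percentage points lower from compound 3 to compound 4 (beyond the scatter) is expected from compound 3 to compound 4, about the size of the earlier drop, because a number 11.1 percentage points lower from compound 1 to compound 2 (beyond the scatter). On that basis compound 4 is estimated at 66% in this assay, with a range from 45% to 82%.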

Compound 4, a percentage reported as inhibition, at one concentration (the size of the read-out at that concentration, not a potency): 78.4%
The estimate for compound 4 lay 12.4 percentage points below the measured number; the range from low to high includes it.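

In this assay, putting (3-chlorophenyl)amino in place of 4-methylpiperidin-1-yl on the core of compound 3 gave a number 0.2 percentage points lower from compound 3 to compound 4 (within the scatter), and this step does not differ meaningfully from the earlier one: the same change on two cores in this assay, a number 11.1 percentage points lower (beyond the scatter) from compound 1 to compound 2 and a number 0.2 percentage points lower (within the scatter) from compound 3 to compound 4, 10.9 percentage points apart, within the scatter of two such steps. Replacing 2-((2-aminophenyl)carbamoyl)ethenyl with (2-aminophenyl)carbamoyl while (3-chlorophenyl)amino is present gave a number 62.6 percentage points higher from compound 2 to compound 4 (beyond the scatter), and this large gain also matches its earlier counterpart: the same change on two cores in this assay, a number 51.7 percentage points higher (beyond the scatter) from compound 1 to compound 3 and a number 62.6 percentage points higher (beyond the scatter) from compound 2 to compound 4, 10.9 percentage points apart, within the scatter of two such steps. Within these four compounds, each change therefore carried from one core to the other within the expected scatter, but each comparison rests on only one pair of steps, so this does not establish a general rule for the series, and the single test concentration gives no measure of potency.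

The compounds shown leave open how other groups at the same aromatic carbon, such as a simple amine or a morpholine ring, would compare with 4-methylpiperidin-1-yl and (3-chlorophenyl)amino. They also leave open whether a saturated two-carbon chain in place of the ethenyl link would behave like the ethenyl compounds or like those with the amide carbonyl joined directly to the ring.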